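The compounds below may be only part of what the source reports. "The series", "measured", "known", "first", "only" and "open" are said of these compounds alone.

Working notes on a small series sharing one core. In a functional assay on NCI-H460 cells (Homo sapiens) for inhibition, read by MTT assay, with a stated time of 24 h, tested at 0.1 ug/mL (on this read-out lower numbers stand for less inhibition of growth and higher numbers for more inhibition of growth at the one concentration tested), compound 1 (`CC(=O)SCCC(CCCCC(=O)Nc1ccccc1)SC(C)=O`) gives 15.4%. Compound 2 (`CC(=O)SCCC(CCCCC(=O)Nc1cccc(Cl)c1)SC(C)=O`) has no number: its result reads "not active" (no number reported), so it cannot be given an exact place on the scale, and its gap to compound 1 cannot be expressed as a numerical step.

The next analogue is compound 3 (`CC(=O)SCCC(CCCCC(=O)Nc1ccc(Cl)cc1)SC(C)=O`). The structural change from compound 2 is 4-chlorophenyl in place of 3-chlorophenyl on an amide-type nitrogen, with the rest of the structure unchanged.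

For the measured compounds named here, no measured step shows what such a change does. Going by the values given here, the only guide is that compound 1 at 15.4% and compound 2 at "not active" (no number reported) both lie low on the scale of this assay. A small step from compound 2 is therefore expected, towards slightly more inhibition of growth if any, and none beyond the scatter. A result without a number would also not be surprising. For compound 3 the estimated inhibition is 8%, with an expected range of 0% to 22%.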

Compound 3, percent growth inhibition at one concentration: 9.89%
Estimate against measurement, compound 3: 1.9 percentage points below, within the range that was stated.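

In this assay compound 3 gives 9.89%, so 4-chlorophenyl on an amide-type nitrogen yields a number where the 3-chlorophenyl of compound 2 yielded none. Chloro in place of hydrogen on an aromatic carbon gives a number 5.5 percentage points lower from compound 1 to compound 3 (within the scatter), the first readable step in the series, which leaves this chlorinated analogue and the unsubstituted phenyl indistinguishable on this read-out, while the step between the two chlorophenyl compounds cannot be read, with compound 2 carrying no number. Nothing shown accounts for the difference in how the two chlorophenyl results were reported.

The compounds shown cover only hydrogen and chloro on the phenyl ring, so it remains open whether a methoxy group, an amine or a carboxylic acid there would lift the result clear of the scatter in this assay. Also open, as far as these compounds go, is what a longer chain in the shared core would do, or free thiol groups in place of the two thioacetate groups, and whether any of these analogues would reach a higher inhibition of growth at the one concentration tested.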